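The source may hold more compounds than are shown below. What is called first, only, known or untested is meant among the compounds shown, and "the series" means these compounds.

Compound 1 `O=S(=O)(Nc1ccc(-c2nc3ccccc3o2)cc1)c1ccc(Cl)c(C(F)(F)F)c1`: in an assay on isolated protein for inhibition of malate dehydrogenase, mitochondrial (Sus scrofa), with stated times of 45 min and 30 min (a higher number here means a weaker inhibitor, a lower number a stronger inhibitor), compound 1 gives > 63000 nM, which is a limit of the assay.
Compound 2 `O=S(=O)(Nc1ccc2oc(-c3ccccc3)nc2c1)c1ccccc1Cl`: in this assay compound 2 gives > 63000 nM, again a limit.
Compound 3 `O=[N+]([O-])c1cc(S(=O)(=O)Nc2ccc(-c3nc4ccccc4o3)cc2)ccc1Cl`: in this assay compound 3 gives > 63000 nM, also a limit.

Compound 1 therefore stands at the limit of this assay, with no number of its own. Within the data shown here, the one step between measured compounds that differ in a single place, a step that the two limits leave unreadable from compound 1 to compound 3, cannot be read either, since the limit of > 63000 nM in this assay, at which 3 of the 3 values shown sit, holds every value shown. Compound 4 `O=S(=O)(Nc1ccc(-c2nc3ccccc3o2)cc1)c1cccc(C(F)(F)F)c1` is the compound still to be measured; its change from compound 1 is hydrogen in place of chloro on an aromatic carbon. Among the measured compounds shown here, no measured step bears on this change, and the values shown give no sign that a number will appear. Compound 4 is therefore expected to sit at the limit too, so that a step that the limit leaves unreadable from compound 1 to compound 4 is expected to be no readable step. The estimate for compound 4 in this assay is 100000 nM, within 30000 nM to 500000 nM.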

Compound 4, half-maximal inhibitory concentration: > 63000 nM
Compound 4: a limit, no number; the forecaster's own chance of this, stated with the estimate: 85%; the middle value is on the limit's open side.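

Among these compounds, compound 1 and compound 4 both stand at a limit with no number of its own, so no step between them can be read: the limit of > 63000 nM in this assay, at which 4 of the 4 values shown sit. The compounds shown leave open which change to the shared core, if any, would give a real number in this assay.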